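Swapping a chain amine for a methylpiperidine

The source may hold more compounds than are shown below. What is called first, only, known or untested is meant among the compounds shown, and "the series" means these compounds.

Compounds measured so far:
- compound 1 `COc1cc(C)c(S(=O)(=O)N(C)CCOCC(=O)N2CCN([C@@H]3CN4CCC3CC4)CC2)c(C)c1` — 8.1
- compound 2 `COc1cc(C)c(S(=O)(=O)N(C)CCOCC(=O)N2CCN(C3CCN(C4CC4)CC3)CC2)c(C)c1` — 8.5
- compound 3 `COc1cc(C)c(S(=O)(=O)N(C)CCOCC(=O)N2CCN(CCCN(C)C)CC2)c(C)c1` — 7.9

All three share one core and differ only in the group on an amine nitrogen in a ring. In a functional assay on Umbilical vein for antagonist activity at B1 bradykinin receptor (Homo sapiens), using Schild analysis, with a stated time of 30 min (on this read-out lower numbers stand for lower potency and higher numbers for higher potency (the scale is a negative logarithm)), compound 3 gives the lowest of the three numbers. Its gap to compound 1 is small, a number 0.20 log units lower from compound 1 to compound 3 (within the scatter), while its gap to compound 2 is larger, a number 0.60 log units lower from compound 2 to compound 3 (beyond the scatter).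

Compound 4 `COc1cc(C)c(S(=O)(=O)N(C)CCOCC(=O)N2CCN(CC3CCN(C)CC3)CC2)c(C)c1` has not yet been measured. The change from compound 3 is 1-methylpiperidin-4-yl in place of 2-(dimethylamino)ethyl on a saturated chain carbon bound to an amine nitrogen in a ring.

For the measured compounds named here, two measured steps bear on this. Both of them replaced a ring-bearing group on that nitrogen with the chain of compound 3, and both moved the numbers down, once within the scatter and once beyond it. Compound 4 goes the other way, back from the chain to a group carrying a six-membered ring, so the expectation is a step upward in this assay, modest in size and closer to the smaller of the two measured steps than to the larger.

Compound 4 is therefore expected to give 8.2, most likely between 7.7 and 8.7, a rise of a number 0.30 log units higher from compound 3 to compound 4 (within the scatter) that is estimated, not measured.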

Compound 4, negative logarithm of the antagonist equilibrium constant: 8.6
Beside the measured number, compound 4's estimate is 0.40 log units below it, within the range that was stated.
By their numbers in this assay, from the lowest: compounds 3 and 1 (each within the scatter of the next); then compounds 2 and 4 (each within the scatter of the next).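

In this assay, putting 1-methylpiperidin-4-yl in place of 2-(dimethylamino)ethyl on a saturated chain carbon bound to an amine nitrogen in a ring gives a number 0.70 log units higher from compound 3 to compound 4 (beyond the scatter) and shows that this position rewards a ring-bearing group even when a chain carbon still links that ring to the core. Two quite different ring-bearing groups can read alike here, as (1-methylpiperidin-4-yl)methyl in place of 1-cyclopropylpiperidin-4-yl gives a number 0.10 log units higher from compound 2 to compound 4 (within the scatter) and so leaves those two compounds level. A ring alone does not settle the matter, however: compound 1 goes against any such rule, since the comparison with its group of two rings gives a number 0.50 log units higher from compound 1 to compound 4 (beyond the scatter) and that compound stays within the scatter of the open chain of compound 3.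

Nothing at hand explains why these groups differ, so the reason for the steps remains open. Also open, as far as these compounds go, is whether the level of compound 4 would hold with an ethyl group in place of the methyl on the ring nitrogen, with a longer chain carrying the same ring, or with a morpholine ring in its place.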